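This account rests on a few compounds, and the source may have more. Where it says the series, first, only, none or still open, it means among the compounds named here.

Working notes on the series.

Three compounds sharing one core have numbers in a functional assay on MGC-803 cells (Homo sapiens) for inhibition, read by MTT assay, with a stated time of 72 h; a lower number here means a stronger inhibitor, a higher number a weaker inhibitor. Compound 1 `N#Cc1c(Nc2cccc(Cl)c2)nc(SCc2cn(Cc3ccccc3Cl)nn2)nc1-c1ccccc1` gives 15800 nM, compound 2 `Cc1cccc(Nc2nc(SCc3cn(Cc4ccccc4Cl)nn3)nc(-c3ccccc3)c2C#N)c1` gives 16200 nM, and compound 3 `N#Cc1c(Nc2ccc(F)cc2)nc(SCc2cn(Cc3ccccc3Cl)nn2)nc1-c1ccccc1` gives 8740 nM. Compound 3 holds the lowest of the three numbers, but its gap to the others is small: the step of a 1.8-fold lower number from compound 1 to compound 3 (0.26 log units; within the scatter) and the step of a 1.9-fold lower number from compound 2 to compound 3 (0.27 log units; within the scatter) both lie within the scatter, so no order among the three can be claimed in this assay.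

Compound 4 `Cc1ccc(Nc2nc(SCc3cn(Cc4ccccc4Cl)nn3)nc(-c3ccccc3)c2C#N)cc1` is the next member to be measured. Relative to compound 3 the change is methyl in place of fluoro on an aromatic carbon. The closest measured step of the same kind is a 1.0-fold higher number from compound 1 to compound 2 (0.01 log units; within the scatter), where one small group at the same kind of position on the aryl amine gave way to methyl with no movement beyond the scatter. The other two steps, which move the substituent between positions, also stay within the scatter. On that basis no step beyond the scatter is expected in this assay for the move to compound 4; the expected step is a 1.2-fold higher number from compound 3 to compound 4 (0.08 log units; within the scatter).

The estimate for compound 4 in this assay is 10500 nM, with a range from 4500 nM to 24000 nM.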

Compound 4, half-maximal inhibitory concentration: 7190 nM
Beside the measured number, compound 4's estimate is 1.5-fold (0.16 log units) above it, within the range that was stated.
By their numbers in this assay, from the lowest: compounds 4, 3, 1 and 2 (each within the scatter of the next, the first and the last beyond it).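

In this assay, fluoro and methyl on an aromatic carbon para to a large group are not told apart, with a 1.2-fold lower number from compound 3 to compound 4 (0.08 log units; within the scatter), so this position accepts either group without a step beyond the scatter. The series now shows its first steps beyond the scatter, though they are modest: a 2.3-fold lower number from compound 2 to compound 4 (0.35 log units; beyond the scatter) for 4-methylphenyl in place of 3-methylphenyl, and a 2.2-fold lower number from compound 1 to compound 4 (0.34 log units; beyond the scatter) for 4-methylphenyl in place of 3-chlorophenyl, which hints at a preference for the 4-substituted aryl amine, but compound 3 goes against that reading, since its steps from compound 1 and compound 2 stay within the scatter. Nothing available here bears on the reason for these numbers.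

The compounds shown leave open whether a larger or charged group at this place, such as methoxy, a dimethylamino group or a carboxylic acid, would produce a step beyond the scatter from compound 4. They also leave open whether the unsubstituted phenyl amine or a 4-chlorophenyl amine would stay with compound 3 and compound 4.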